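The source may hold more compounds than are shown below. What is called first, only, known or untested is meant among the compounds shown, and "the series" means these compounds.

Measured compounds:
Compound 1 `COc1cc(-c2nn(-c3cccc(NC(=O)Nc4cc(C(F)(F)F)cc(C(F)(F)F)c4)c3)cc2-c2ccncc2)ccc1Cl` — 1360 nM
Compound 2 `O=C(Nc1cccc(-n2cc(-c3ccncc3)c(-c3ccc(Cl)c(O)c3)n2)c1)Nc1ccc(Cl)c(Cl)c1` — 1510 nM

In a functional assay on NCI-H226 cells (Homo sapiens) for inhibition, read by sulforhodamine B assay, with a stated time of 48 h (a higher number here means a weaker inhibitor of growth, a lower number a stronger inhibitor of growth), compound 1 gives 1360 nM, the lowest of the two numbers shown, and compound 2 gives 1510 nM, a value within the scatter of that of compound 1. Compound 3 `COc1cc(-c2nn(-c3cccc(NC(=O)Nc4cccc(C(F)(F)F)c4)c3)cc2-c2ccncc2)ccc1Cl` has not yet been measured. It differs from compound 1 in one place: hydrogen in place of trifluoromethyl on an aromatic carbon, a hydrogen in place of trifluoromethyl on an aromatic carbon. Going by the values given here, no measured step of this kind is available here. The expectation is a modest weakening, a step from a 1.8-fold higher number from compound 1 to compound 3 (0.26 log units; within the scatter), toward a higher number in this assay. Compound 3 is therefore estimated at 2500 nM, in a range from 900 nM to 7000 nM.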

Compound 3, concentration for 50% growth inhibition: 1380 nM
Beside the measured number, compound 3's estimate is 1.8-fold (0.26 log units) above it; low and high end bracket the measured number.
By their numbers in this assay, from the lowest: compounds 1, 3 and 2 (each within the scatter of the next).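

In this assay, going by these compounds alone, hydrogen in place of trifluoromethyl on an aromatic carbon gives a 1.0-fold higher number from compound 1 to compound 3 (0.01 log units; within the scatter), the first step here that isolates a single position. At this position, meta to a trifluoromethyl group, this group can therefore leave without the number moving beyond the scatter. Nothing measured here gives a reason for this. The compounds shown leave open whether an amine or a carboxylic acid at this position would also stay within the scatter. They also leave open whether the remaining trifluoromethyl group can be replaced by hydrogen.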